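The source may report more compounds than this note shows. Statements on the series, on what has been measured and on what is new or still open speak of the compounds shown alone.

Measured compounds in a functional assay on DU-145 cells (Homo sapiens) for antiproliferative activity, read by MTT assay, with a stated time of 48 h; a higher number here means a weaker inhibitor, a lower number a stronger inhibitor:

Compound 1, `C/C(=C\CC/C(C)=C/CC[C@@H]1[C@@]2(C)CCC(=O)C(C)(C)[C@H]2CC[C@@]1(C)O)CC/C=C(\C)C(=O)OCc1cn(-c2ccccc2[N+](=O)[O-])nn1`: compound 1 gives > 150000 nM, a limit of the assay.
Compound 2, `C/C(=C\CC/C(C)=C/CC[C@@H]1[C@@]2(C)CCC(=O)C(C)(C)[C@H]2CC[C@@]1(C)O)CC/C=C(\C)C(=O)OCc1cn(-c2cccc([N+](=O)[O-])c2)nn1`: compound 2 gives > 150000 nM, a limit of the assay.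
Compound 3, `C/C(=C\CC/C(C)=C/CC[C@@H]1[C@@]2(C)CCC(=O)C(C)(C)[C@H]2CC[C@@]1(C)O)CC/C=C(\C)C(=O)O`: compound 3 gives > 150000 nM, a limit of the assay.

Compound 2 stands only at a limit in this assay, and the two further values shown stand at the same limit, as the limit of > 150000 nM in this assay, at which 3 of the 3 values shown sit, records. Going by the values given here, the one step between measured compounds that differ in a single place, a step that the two limits leave unreadable from compound 1 to compound 2, is therefore of unreadable size, with both ends at the limit.

Compound 4, `COc1cccc(-n2cc(COC(=O)/C(C)=C/CC/C(C)=C/CC/C(C)=C/CC[C@@H]3[C@@]4(C)CCC(=O)C(C)(C)[C@H]4CC[C@@]3(C)O)nn2)c1`, is not yet measured in this assay. It differs from compound 2 in one place: methoxy in place of nitro on an aromatic carbon. No measured step touches this change; the only measured step sets neither direction nor size, so nothing in the numbers shown points to a gain or a loss for compound 4 relative to compound 2. The step that the limit leaves unreadable from compound 2 to compound 4 is therefore estimated as none beyond the scatter, with the assay expected to report a limit again. Compound 4 is expected at 200000 nM in this assay, in a range from 100000 nM to 500000 nM, most probably as a limit rather than a number.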

Compound 4, half-maximal inhibitory concentration: > 150000 nM
Compound 4 gave a limit, no number; the forecaster's own chance of this, stated with the estimate: 85%; the middle value is on the limit's open side.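

No new step can be read from compound 1 or compound 2 to compound 4, because all of these compounds, like compound 3, stand at one and the same limit and not at a number: the limit of > 150000 nM in this assay, at which 4 of the 4 values shown sit.

The compounds shown leave open whether any change to the shared core or its substituents would give a number rather than a limit.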